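This account rests on a few compounds, and the source may have more. Where it says the series, first, only, none or still open, it means among the compounds named here.

Series notes, binding at the bovine adenosine receptor.

Compound 1, `Cc1cccc(Nc2ncnc3c2nnn3Cc2ccccc2)c1`, in an assay on cell membranes for binding affinity to adenosine receptor A1 (Bos taurus), read by radioligand binding (on this read-out higher numbers stand for weaker inhibition and lower numbers for stronger inhibition), gives 1100 nM. Compound 2, `Cc1cccc(Nc2ncnc3c2nnn3Cc2ccccc2Cl)c1`, carries one change against compound 1, (chloro in place of hydrogen on an aromatic carbon), and in this assay compound 2 gives 5880 nM. The step is a 5.3-fold higher number from compound 1 to compound 2 (0.73 log units; beyond the scatter).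

Compound 3, `O=[N+]([O-])c1ccc(CNc2ncnc3c2nnn3Cc2ccccc2)cc1`, shares the core with compound 1, but the difference between the two cores is not broken down here. In this assay compound 3 gives only a limit, > 1000 nM. One of the three values shown sits at that limit, (the limit of > 1000 nM in this assay, at which 1 of the 3 values shown sits).

Compound 4, `O=[N+]([O-])c1ccc(CNc2ncnc3c2nnn3Cc2ccccc2Cl)cc1`, is not yet measured. It stands to compound 3 as compound 2 stands to compound 1: chloro in place of hydrogen on an aromatic carbon. The place of the change reads the same in both pairs, so it is taken as the same change. For the measured compounds named here, on the single measured step the same change gave a weaker number, and from that compound 4 is expected to move by a step that the limit leaves unreadable from compound 3 to compound 4. Since compound 3 itself stands at a limit, compound 4 is estimated at 6000 nM, between 1500 nM and 25000 nM, and will most likely also be reported only as a limit.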

Compound 4, inhibition constant: > 1000 nM
Compound 4: a limit, no number; the forecaster's own chance of this, stated with the estimate: 75%; the middle value does not contradict the limit.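

In this assay compound 4 gives only a limit, > 1000 nM. Compound 3 also stands at a limit, so no step can be read between compound 3 and compound 4: the limit of > 1000 nM in this assay, at which 2 of the 4 values shown sit.

The compounds shown leave open whether chloro in place of hydrogen on an aromatic carbon shifts compound 3 as it shifts compound 1.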